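Chloro to Methoxy Swap: An Estimate for Compound 4

The compounds below may be only part of what the source reports. "The series", "measured", "known", "first", "only" and "open" are said of these compounds alone.

Compound 1 `O=C(O)Cn1c(SCc2ccc(Cl)cc2)nc2ccccc21`: 160 nM
Compound 2 `O=C(O)Cn1c(SCc2cccc(Cl)c2)nc2ccccc21`: 186 nM
Compound 3 `COc1ccc(CSc2nc3ccccc3n2CC(=O)O)cc1`: 210 nM

The three measured compounds were tested in an assay on HEK293 cells for displacement of a labelled ligand from prostaglandin D2 receptor 2 (Homo sapiens); a lower number here means a stronger inhibitor, a higher number a weaker inhibitor. Compound 1 and compound 2 share the same atoms joined differently: 3-chlorophenyl in place of 4-chlorophenyl on a saturated chain carbon bound to a sulfur. That change gave a 1.2-fold higher number from compound 1 to compound 2 (0.07 log units; within the scatter). Compound 3 differs from compound 1 by methoxy in place of chloro on an aromatic carbon, and that step was a 1.3-fold higher number from compound 1 to compound 3 (0.12 log units; within the scatter). Compound 4 `COc1cccc(CSc2nc3ccccc3n2CC(=O)O)c1` has not yet been measured. For the measured compounds named here, it differs from compound 2 by methoxy in place of chloro on an aromatic carbon, the same kind of change as the one leading to compound 3, though in compound 4 the methoxy sits meta to a large group while in compound 3 it sits para to a large group. Going by the values given here, the one measured example of this change, a 1.3-fold higher number from compound 1 to compound 3 (0.12 log units; within the scatter), stayed within the scatter, so a similarly small step is expected for compound 4, resting on compound 2 at 186 nM and on that earlier step. The expected step from compound 2 to compound 4 is a 1.2-fold higher number from compound 2 to compound 4 (0.09 log units; within the scatter). Compound 4 is estimated at 230 nM in this assay, with a likely range from 120 nM to 450 nM.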

Compound 4, half-maximal inhibitory concentration: 72 nM
Compound 4: middle estimate off by 3.2-fold (0.50 log units), on the high side, and the stated range ends above it.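

In this assay, methoxy in place of chloro on an aromatic carbon, meta to a large group, gave a 2.6-fold lower number from compound 2 to compound 4 (0.41 log units; beyond the scatter). Set beside the earlier case, the same change did not carry over from one core to the other: the same change on two cores in this assay, a 1.3-fold higher number (0.12 log units; within the scatter) from compound 1 to compound 3 and a 2.6-fold lower number (0.41 log units; beyond the scatter) from compound 2 to compound 4, 3.4-fold (0.53 log units) apart, beyond the scatter of two such steps. For the compounds shown here, this shows that, in this series, the step measured on compound 1 did not predict the step on compound 2, so the size and direction of this change depended on the compound that carried it; with only two examples, however, it does not establish a general rule for either chloro position, and it does not show what lies behind the difference.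

The compounds shown carry only chloro or methoxy on that aromatic ring, so it remains open whether fluoro or an amine there would follow the step from compound 1 or the step from compound 2. Also open, as far as these compounds go, is what a longer chain on the sulfur would do to the same change.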